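From 4-chlorobenzyl to 4-fluorobenzyl: notes on compound 4

The compounds below may be only part of what the source reports. "The series", "measured", "known", "first", "only" and "open" are said of these compounds alone.

Measured so far in a functional assay on HCT-116 cells (Homo sapiens) for antiproliferative activity, read by MTT assay, with a stated time of 48 h; on this read-out higher numbers stand for weaker inhibition and lower numbers for stronger inhibition:
- compound 1 `COc1ccc(CN(C(=O)CSc2nc3ccccc3s2)c2cc(OC)c(OC)c(OC)c2)cc1N=[N+]=[N-]`: 2860 nM
- compound 2 `COc1ccc(CN(C(=O)CSc2nc3ccccc3s2)c2cc(OC)c(OC)c(OC)c2)cc1O`: 182 nM
- compound 3 `COc1cc(N(Cc2ccc(Cl)cc2)C(=O)CSc2nc3ccccc3s2)cc(OC)c1OC`: 603000 nM

Compound 3 has the highest number of the three at 603000 nM, which makes it the weakest of this set. The next compound for measurement is compound 4 `COc1cc(N(Cc2ccc(F)cc2)C(=O)CSc2nc3ccccc3s2)cc(OC)c1OC`. It carries fluoro in place of chloro on an aromatic carbon, para to a large group: fluoro in place of chloro on an aromatic carbon.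

Two measured steps reach this part of the structure: a 210-fold higher number from compound 1 to compound 3 (2.32 log units; beyond the scatter) and a 3300-fold higher number from compound 2 to compound 3 (3.52 log units; beyond the scatter). Both are large, but each exchanges the whole group that carries the halogen, so neither is a direct guide to a swap of one halogen for another. Within the data shown here, compounds 1 and 2 contain no halogen, and no measured pair isolates this change. The step of a 16-fold lower number from compound 1 to compound 2 (1.20 log units; beyond the scatter) is also large and shows that a single substituent exchange can move the number a long way in this series.

In this assay, no step beyond the scatter is therefore expected, but with low confidence. The expected step is a 1.7-fold lower number from compound 3 to compound 4 (0.24 log units; within the scatter). For compound 4 the estimated value is 350000 nM, with an expected range of 50000 nM to 1000000 nM.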

Compound 4, half-maximal inhibitory concentration: 59800 nM
Compound 4: the middle estimate sits 5.9-fold (0.77 log units) above what was measured, within the range that was stated.
By their numbers in this assay, from the lowest: compound 2; then compound 1; then compound 4; then compound 3.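

In this assay, among these compounds, the identity of the halogen on this aromatic carbon is not a neutral detail: fluoro in place of chloro gives the first measured step that isolates this one-atom exchange (a 10-fold lower number from compound 3 to compound 4 (1.00 log units; beyond the scatter)). The 4-fluorobenzyl group still leaves compound 4 well short of the two compounds without halogen, with 4-fluorophenyl in place of 3-hydroxy-4-methoxyphenyl (a 330-fold higher number from compound 2 to compound 4 (2.52 log units; beyond the scatter)) and 4-fluorophenyl in place of 3-azido-4-methoxyphenyl (a 21-fold higher number from compound 1 to compound 4 (1.32 log units; beyond the scatter)). Both halogen-bearing compounds therefore have higher numbers than compounds 1 and 2, so the halogen exchange changes the number considerably without closing the distance to the hydroxy compound, and a single pair of halogens gives no trend across this position.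

Nothing available bears on why the number moves with this exchange. Also open, from the compounds shown here alone, is how an amine or a carboxylic acid on the same aromatic carbon, para to a large group, would compare with chloro and fluoro, and whether the step seen here would hold on a core carrying the 3-hydroxy-4-methoxyphenyl group.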